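The source may hold more compounds than are shown below. What is called first, only, known or untested is meant among the compounds shown, and "the series" means these compounds.

Measured compounds:
compound 1 `N=C(NO)N/N=C/c1ccc(Cl)cc1`: > 100000 nM
compound 2 `COc1ccccc1/C=N/N=C(\N)NO`: > 100000 nM
compound 3 `N/C(=N\O)N/N=C/c1ccccc1O`: > 100000 nM

The read-out throughout is an ADME assay on Vero cells (Chlorocebus sabaeus) for cytotoxicity; a lower number here means that less compound is tolerated, a higher number that more compound is tolerated. Compound 1 sits at a limit of this assay rather than at a number. The same holds for compound 2, whose value is likewise only a limit. Compound 3 too returns nothing but a limit. All three values therefore rest at one point, namely (the limit of > 100000 nM in this assay, at which 3 of the 3 values shown sit), and no ordering of the three compounds can be read from them. Among the compounds with values here, no step between measured compounds that differ in a single place is available in this set, so the size of any single change remains unmeasured.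

Compound 4 `N=C(NO)N/N=C/c1ccccc1`, not yet measured, differs from compound 1 by hydrogen in place of chloro on an aromatic carbon. Within the data shown here, with every measured value resting at the limit, there is no measured step to lean on. The step is expected to be none beyond the scatter, a step that the limit leaves unreadable from compound 1 to compound 4. Compound 4 is expected to return only a limit again, most likely. For compound 4 in this assay the estimate is 150000 nM, within 50000 nM to 500000 nM.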

Compound 4, half-maximal cytotoxic concentration: > 100000 nM
Compound 4 ended at the assay's limit; the forecaster's own chance of this, stated with the estimate: 85%; the middle value does not contradict the limit.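

Compound 1 and compound 4 yield no readable step in this assay, because both values are limits of the assay and not numbers: the limit of > 100000 nM in this assay, at which 4 of the 4 values shown sit.

The compounds shown leave open any ordering within the series, and also the size, if any, of the effect of hydrogen in place of chloro on an aromatic carbon.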